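The source may hold more compounds than are shown below. What is called first, only, known or untested is meant among the compounds shown, and "the series" means these compounds.

Measured so far:
compound 1, `O=C(C1=C(O)C(=O)N(CCCn2ccnc2)C1c1ccc(Br)cc1)c1ccccc1`, a functional assay on U2OS cells (Homo sapiens) for antiproliferative activity, read by MTT assay, with a stated time of 72 h; a lower number here means a stronger inhibitor, a higher number a weaker inhibitor: "not active" (no number reported)
compound 2, `CCOc1ccc(NC2=C(C(=O)c3ccccc3)C(c3ccc(Br)cc3)N(CCCn3ccnc3)C2=O)cc1`, this assay: 26200 nM

Among the measured compounds shown here, compound 2 holds the only number in this assay, so it stands alone there, and compound 1 is recorded in this assay as "not active" (no number reported), without a number. Compound 3, `O=C(C1=C(Nc2ccc(Cl)cc2)C(=O)N(CCCn2ccnc2)C1c1ccc(Br)cc1)c1ccccc1`, is not yet measured. It differs from compound 2 by chloro in place of ethoxy on an aromatic carbon. For the measured compounds named here, no step between two measured compounds is available to gauge this exchange, so the size of the step rests on the single value of compound 2. The step from compound 2 to compound 3 is expected to be a 1.2-fold lower number from compound 2 to compound 3 (0.08 log units; within the scatter), a change not clearly beyond the scatter and without a firm direction. Compound 3 is therefore estimated at 22000 nM in this assay, within a range from 7000 nM to 70000 nM.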

Compound 3, half-maximal inhibitory concentration: 22800 nM
Compound 3: middle estimate off by 1.0-fold (0.02 log units), on the low side; measured number inside the range.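

In this assay, among the compounds shown here, replacing (4-ethoxyphenyl)amino with (4-chlorophenyl)amino gives a 1.1-fold lower number from compound 2 to compound 3 (0.06 log units; within the scatter), the first step that can be read at this position. On this aromatic carbon, para to a large group, an ethoxy of three heavy atoms with one hydrogen-bond acceptor can thus give way to a single chlorine without the two compounds separating beyond the usual scatter. Nothing measured here offers an explanation for this result.

With a single exchange to go on, no trend across substituents at this position can be drawn. As far as these compounds go, it remains open whether an amine, a carboxylic acid or a longer alkoxy chain in this place would shift the number in this assay beyond the scatter, and in which direction.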